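Acetylating the Hydroxy Group of Compound 1

The source may hold more compounds than are shown below. What is called first, only, known or untested is meant among the compounds shown, and "the series" means these compounds.

- Compound 1 `COc1cc(C(O)c2ccc3c(ccn3C)c2)cc(OC)c1OC`: > 10000 nM (a limit)
- Compound 2 `CCn1ccc2cc(C(O)c3cc(OC)c(OC)c(OC)c3)ccc21`: > 10000 nM (a limit)

In a functional assay on HL-60 cells (Homo sapiens) for cytotoxicity, read by XTT assay, with a stated time of 72 h (on this read-out higher numbers stand for weaker inhibition and lower numbers for stronger inhibition), compound 1 gives only a limit, > 10000 nM, and not a number. Compound 2 also gives only a limit, > 10000 nM. The measured data amount to the limit of > 10000 nM in this assay, at which 2 of the 2 values shown sit. Among the measured compounds shown here, the one measured step is a step that the two limits leave unreadable from compound 1 to compound 2, with methyl in place of hydrogen on a saturated chain carbon bound to an aromatic nitrogen. It sits elsewhere in the molecule and offers no size to carry over.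

Compound 3 `COc1cc(C(OC(C)=O)c2ccc3c(ccn3C)c2)cc(OC)c1OC` changes the hydroxy group instead: acetyl in place of hydrogen on an oxygen on a saturated carbon. In short, this is hydroxy to acetoxy. For the measured compounds named here, no measured step touches this place. Compound 1 offers the limit > 10000 nM as its only starting point, so no clear step in either direction is expected in this assay, and another limit is the likeliest report. The expected change is a number no higher from compound 1 to compound 3 (the limit leaves the size open). Compound 3 is estimated at 10000 nM, with an expected range of 2000 nM to 30000 nM.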

Compound 3, half-maximal inhibitory concentration: 240 nM
Estimate against measurement, compound 3: 42-fold (1.62 log units) above; measured number outside the range, below it.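

The hydroxy group of compound 1 proves to be a place where a single change registers clearly in this assay: acetyl in place of the hydroxy hydrogen gives an at least 41-fold lower number from compound 1 to compound 3 (1.61 log units; beyond the scatter). The true size of this step may be larger, as the starting value for compound 1 is only a limit. Compound 3 is the only compound shown with a number rather than a limit, and the other values stay limits: the limit of > 10000 nM in this assay, at which 2 of the 3 values shown sit.

As far as these compounds go, whether a methyl ether, a longer ester such as butanoyl, or an amine at this place would give a similar number remains open. From the compounds shown here alone, the step from compound 1 to compound 2 cannot be read, and it also remains open how the larger group on the aromatic nitrogen of compound 2 would behave alongside acetoxy.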